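Fluorophenyl for methoxyphenyl on the benzophenone of compound 1

This account rests on a few compounds, and the source may have more. Where it says the series, first, only, none or still open, it means among the compounds named here.

Compound 1 `COc1cccc(C(=O)c2ccc(OC)c(OC(=O)CCC(=O)OC[C@@H]3C=C[C@H](n4cc(C)c(=O)[nH]c4=O)O3)c2)c1` gives 820 nM in a functional assay on SMMC-7721 cells (Homo sapiens) for antiproliferative activity, read by MTT assay, with a stated time of 48 h (on this read-out higher numbers stand for weaker inhibition and lower numbers for stronger inhibition), the lowest of the three numbers recorded. Compound 2 `COc1ccc(C(=O)c2cccc(Cl)c2)cc1OC(=O)CCC(=O)OC[C@@H]1C=C[C@H](n2cc(C)c(=O)[nH]c2=O)O1` gives 3210 nM; the step of a 3.9-fold higher number from compound 1 to compound 2 (0.59 log units; beyond the scatter) is beyond the scatter. Compound 3 `COc1ccc(C(=O)c2ccccc2OC)cc1OCC(=O)OC[C@@H]1C=C[C@H](n2cc(C)c(=O)[nH]c2=O)O1` gives 32300 nM; it differs from compound 1 in more than one place, so only the two values stand side by side.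

Compound 4 `COc1ccc(C(=O)c2ccc(F)cc2)cc1OC(=O)CCC(=O)OC[C@@H]1C=C[C@H](n2cc(C)c(=O)[nH]c2=O)O1` is not yet measured. It differs from compound 1 by 4-fluorophenyl in place of 3-methoxyphenyl on a carbonyl carbon. Going by the values given here, the one step that bears on it is the halogen-for-methoxy exchange on the same aromatic ring: a 3.9-fold higher number from compound 1 to compound 2 (0.59 log units; beyond the scatter) raised the number by a modest amount. A halogen again replaces the methoxy here, though at another position on the ring and with fluorine in place of chlorine, so a step of similar kind but uncertain size is expected, upward in this assay. The step of a 2.4-fold higher number from compound 1 to compound 4 (0.39 log units; beyond the scatter) is the expected outcome. Compound 4 is estimated at 2000 nM, within 700 nM to 6000 nM.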

Compound 4, half-maximal inhibitory concentration: 22600 nM
Compound 4: the middle estimate sits 11-fold (1.05 log units) below what was measured; measured number above the stated range.
By their numbers in this assay, from the lowest: compound 1; then compound 2; then compounds 4 and 3 (each within the scatter of the next).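

In this assay, the group on this carbonyl carbon tolerates less than the chloro step alone suggested: the change to 4-fluorophenyl gives a 28-fold higher number from compound 1 to compound 4 (1.44 log units; beyond the scatter), a large step. Replacing the methoxy with a halogen therefore has no single size here, since 3-chlorophenyl and 4-fluorophenyl also stand apart, with a 7.0-fold higher number from compound 2 to compound 4 (0.85 log units; beyond the scatter), a modest step beyond the scatter. In that pair, the halogen and its place on the ring change together, so the step cannot be assigned to either one.

Going by these compounds, whether the halogen or its place on the ring accounts for the gap remains open, as does how a phenyl bearing an amine or a carboxylic acid would behave on the same carbonyl carbon. No measurement shown here bears on the reason for these steps.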